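Moving the fluorine on the benzyl group of compound 3

The source may report more compounds than this note shows. Statements on the series, on what has been measured and on what is new or still open speak of the compounds shown alone.

Of the compounds shown here, three built on a shared core have so far been measured in a functional assay on HT-29 cells (Homo sapiens) for inhibition, read by MTT assay, with a stated time of 48 h; a higher number here means a weaker inhibitor, a lower number a stronger inhibitor. Compound 1 `O=C(NC(=S)Nc1ccc(Cl)c(-c2nc3ccccc3[nH]2)c1)c1ccc(OCc2ccc(Cl)c(Cl)c2)cc1` gives 4930 nM in this assay. Compound 2 `Cc1ccc(NC(=O)NC(=O)c2ccc(OCc3cccc(C(F)(F)F)c3)cc2)cc1-c1nc2ccccc2[nH]1` gives 3520 nM in this assay. Compound 3 `Cc1ccc(NC(=O)NC(=O)c2ccc(OCc3ccccc3F)cc2)cc1-c1nc2ccccc2[nH]1` gives 760 nM in this assay, the lowest of the three numbers; its nearest neighbour is compound 2, and compound 1 stands furthest away, both steps beyond the scatter.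

Within the data shown here, the one measured step that touches the benzyl group is a 4.6-fold lower number from compound 2 to compound 3 (0.67 log units; beyond the scatter), which shows that the group carried on the saturated chain carbon bound to the ring oxygen can move the number by a modest amount.

Compound 4 `Cc1ccc(NC(=O)NC(=O)c2ccc(OCc3ccc(F)cc3)cc2)cc1-c1nc2ccccc2[nH]1` has the same atoms as compound 3, joined differently: 4-fluorophenyl in place of 2-fluorophenyl on a saturated chain carbon bound to an oxygen on an aromatic ring. Among the measured compounds shown here, no measured pair shows the fluorine moved within that ring, so the step from compound 2 to compound 3 bears on it only loosely, as evidence that this part of the molecule is not inert. The expected step of a 1.6-fold higher number from compound 3 to compound 4 (0.20 log units; within the scatter) is therefore small, a slight weakening at most, and it may lie within the scatter. Compound 4 is estimated to give 1200 nM in this assay, within a range from 400 nM to 3600 nM.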

Compound 4, half-maximal inhibitory concentration: 980 nM
Compound 4: middle estimate off by 1.2-fold (0.09 log units), on the high side, and the stated range covers the measured number.
By their numbers in this assay, from the lowest: compounds 3 and 4 (each within the scatter of the next); then compounds 2 and 1 (each within the scatter of the next).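

In this assay, placing the fluorine as 4-fluorophenyl rather than 2-fluorophenyl on the saturated chain carbon bound to an oxygen on an aromatic ring gives a result that cannot be told apart from no change (a 1.3-fold higher number from compound 3 to compound 4 (0.11 log units; within the scatter)), so this move of the fluorine has no readable effect on the number. The replacement of 3-(trifluoromethyl)phenyl now has two measured versions, the earlier one (a 4.6-fold lower number from compound 2 to compound 3 (0.67 log units; beyond the scatter)) and the new one (a 3.6-fold lower number from compound 2 to compound 4 (0.56 log units; beyond the scatter)), so the separation from compound 2 is not tied to a single fluorine placement but holds for both fluorophenyl groups shown. Nothing available explains why these numbers fall as they do.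

The compounds shown leave open whether the fluorine itself matters, which plain phenyl on the same carbon would test, and how a ring bearing an amine or a carboxylic acid at this place would read. Compound 1 differs from the others in more than one place, so it adds nothing about this position.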